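The source may hold more compounds than are shown below. What is called first, only, known or untested is meant among the compounds shown, and "the series" means these compounds.

Among the compounds with values here, compound 2 `O=C(Nc1ccc(Oc2ccnc3[nH]ccc23)c(F)c1)c1cn(-c2ccccc2)c2ccccc2c1=O` holds the lower of the two numbers measured so far in a functional assay on HepG2 cells (Homo sapiens) for inhibition, read by MTT assay, with a stated time of 72 h; on this read-out lower numbers stand for stronger inhibition and higher numbers for weaker inhibition: in it compound 2 gives 760 nM, whereas compound 1 `O=C(Nc1ccc(Oc2ccnc3[nH]ccc23)cc1)c1cn(-c2ccccc2)c2ccccc2c1=O` gives 2250 nM. Within the data shown here, the single measured step, a 3.0-fold lower number from compound 1 to compound 2 (0.47 log units; beyond the scatter), concerns fluoro in place of hydrogen on an aromatic carbon and leaves the group on the aromatic nitrogen untouched. Compound 3 `O=C(Nc1ccc(Oc2ccnc3[nH]ccc23)c(F)c1)c1cn(-c2ccc(C(F)(F)F)cc2Cl)c2ccccc2c1=O` differs from compound 2 at that other place: 2-chloro-4-(trifluoromethyl)phenyl in place of phenyl on an aromatic nitrogen. Among the measured compounds shown here, none of the measured steps bears on a change at this position; the step from compound 1 to compound 2 is the only one available, and it sits elsewhere in the shared core. For the measured compounds named here, with no comparable step in hand, the expected step of a 1.3-fold lower number from compound 2 to compound 3 (0.10 log units; within the scatter) in this assay is set close to no change beyond the scatter, and the range around it is kept wide in both directions. Compound 3 is therefore estimated at 600 nM in this assay, with a range from 150 nM to 2500 nM.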

Compound 3, half-maximal inhibitory concentration: 1840 nM
The estimate for compound 3 lay 3.1-fold (0.49 log units) below the measured number, within the range that was stated.
By their numbers in this assay, from the lowest: compound 2; then compounds 3 and 1 (each within the scatter of the next).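

In this assay, within the data shown here, the group on the aromatic nitrogen proves able to move the number: 2-chloro-4-(trifluoromethyl)phenyl in place of phenyl gives a 2.4-fold higher number from compound 2 to compound 3 (0.38 log units; beyond the scatter) in the only step measured at this position. This runs the opposite way to the earlier change on the aromatic carbon, a 3.0-fold lower number from compound 1 to compound 2 (0.47 log units; beyond the scatter), so of the two groups compared on the fluoro-bearing scaffold, phenyl holds the lower number and the larger substituted ring gives up much of what the fluoro step had gained. Nothing in hand gives a reason for this step, as no measurement beyond the read-out itself accompanies these compounds.

The entering group brings its chloro and its trifluoromethyl together, so the compounds shown leave open how much of the step belongs to each, and whether either alone would change the number at all. They also leave open how a simple methyl, a longer alkyl chain, or a phenyl carrying an amine or a carboxylic acid would read on the same aromatic nitrogen.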